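The source may hold more compounds than are shown below. What is called first, only, known or untested is meant among the compounds shown, and "the series" means these compounds.

In a functional assay (spleen, spleen) for activation, with Mus musculus as the target (a lower number here means that less compound is needed, a higher number that more compound is needed for the effect), three close analogues have been measured. Compound 1 `CSc1nc(N)c2nc(O)n(Cc3ccccc3)c2n1` gives 0.1 uM. Compound 2 `Cc1nc(N)c2nc(O)n(Cc3ccccc3)c2n1` gives 1 uM, with methyl in place of methylsulfanyl on an aromatic carbon, a step of a 10-fold higher number from compound 1 to compound 2 (1.00 log units; beyond the scatter). Compound 3 `CCCCCSc1nc(N)c2nc(O)n(Cc3ccccc3)c2n1` gives 10 uM; it has the highest number of the three, standing a step of a 10-fold higher number from compound 2 to compound 3 (1.00 log units; beyond the scatter) away from compound 2 and a step of a 100-fold higher number from compound 1 to compound 3 (2.00 log units; beyond the scatter) away from compound 1.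

Compound 4 `CCCc1nc(N)c2nc(O)n(Cc3ccccc3)c2n1` is the next compound, not yet measured. It differs from compound 3 by propyl in place of pentylsulfanyl on an aromatic carbon. Two of the measured steps bear on this change. Lengthening the chain on the aromatic carbon, from methyl to pentylsulfanyl, gave a 10-fold higher number from compound 2 to compound 3 (1.00 log units; beyond the scatter), and exchanging methylsulfanyl for methyl gave a 10-fold higher number from compound 1 to compound 2 (1.00 log units; beyond the scatter). Propyl is shorter than pentylsulfanyl and, like methyl in compound 2, carries no sulfur, so a lower number than compound 3 is expected, but not a return to compound 1. Compound 4 is therefore expected to show a step of a 3.3-fold lower number from compound 3 to compound 4 (0.52 log units; beyond the scatter), landing near compound 2. The estimate for compound 4 is 3 uM, with a range from 0.5 uM to 30 uM.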

Compound 4, minimum effective concentration: 1 uM
Beside the measured number, compound 4's estimate is 3.0-fold (0.48 log units) above it; the measured number falls inside the stated range.
By their numbers in this assay, from the lowest: compound 1; then compounds 2 and 4 (each within the scatter of the next); then compound 3.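

In this assay, replacing pentylsulfanyl with propyl on the aromatic carbon between two ring nitrogen atoms gave a clear change (a 10-fold lower number from compound 3 to compound 4 (1.00 log units; beyond the scatter)), so a group on this carbon need not hold sulfur to move the number, and the pentylsulfanyl compound remains the highest of the four. Extending methyl to propyl, by contrast, had no effect beyond the scatter (no change at the digits printed from compound 2 to compound 4 (within the scatter)), which shows that among the two groups joined through carbon, the added ethyl length left the result unchanged. Propyl also stands apart from methylsulfanyl (a 10-fold higher number from compound 1 to compound 4 (1.00 log units; beyond the scatter)), a step of the same printed size as the one for methyl (a 10-fold higher number from compound 1 to compound 2 (1.00 log units; beyond the scatter)), so neither carbon-linked group reaches the low number of the methylsulfanyl compound, while the longer sulfur-linked pentylsulfanyl group goes against any simple rule that sulfur lowers the number.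

The compounds shown leave open whether ethylsulfanyl or propylsulfanyl would stay near methylsulfanyl, whether a pentyl chain would match propyl or pentylsulfanyl, and how an amine at this carbon would read. The available data offer no measured basis for explaining these differences.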